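This account rests on a few compounds, and the source may have more. Where it says the series, first, only, none or still open, it means among the compounds named here.

Measured so far in an ADME assay on MCF7 cells (Homo sapiens) for cytotoxicity, with a stated time of 72 h; a higher number here means a weaker inhibitor, a lower number a stronger inhibitor:

Compound 1 `COc1ccc(CNc2ncnc3c2ncn3C2CCCCO2)c(OC)c1` gives > 25000 nM, which is a limit of the assay.
Compound 2 `COc1ccc(CNc2ncnc3c2ncn3C2CCCCO2)c(OC)c1OC` gives > 37500 nM, also a limit.
Compound 3 `COc1cccc(CNc2ncnc3c2ncn3C2CCCO2)c1` gives > 100000 nM, again a limit.

From compound 1 to compound 2 the change is methoxy in place of hydrogen on an aromatic carbon. The resulting step that the two limits leave unreadable from compound 1 to compound 2 cannot be read, since both ends sit at limits (the limit of > 25000 nM in this assay, at which 1 of the 3 values shown sits, (the limit of > 37500 nM in this assay, at which 1 of the 3 values shown sits)). The difference between the core of compound 1 and the core of compound 3 is not broken down here.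

Compound 4 `COc1cc(CNc2ncnc3c2ncn3C2CCCO2)cc(OC)c1` has not yet been tested in this assay. From compound 3 it differs by methoxy in place of hydrogen on an aromatic carbon, the same kind of change as from compound 1 to compound 2, but placed meta to a methoxy group rather than ortho to two methoxy groups. Among the compounds with values here, compound 3 stands at the limit (the limit of > 100000 nM in this assay, at which 1 of the 3 values shown sits), and the one measured example of this change gave no readable size, so little movement is expected and the step of a number no higher from compound 3 to compound 4 (the limit leaves the size open) is estimated as small. Compound 4 is therefore expected to give 100000 nM, with an estimated range from 30000 nM to 300000 nM, most likely reported only as a limit.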

Compound 4, half-maximal inhibitory concentration: > 100000 nM
Compound 4 ended at the assay's limit (the forecaster's own chance of this, stated with the estimate: 85%); the middle value lies on the limit itself.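

Compound 3 and compound 4 both sit at a limit in this assay, so the step between them cannot be read. The compounds shown leave open whether methoxy in place of hydrogen on an aromatic carbon changes the value at all.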